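From a fluorinated aryl group to a heavier one

The compounds below may be only part of what the source reports. "The series", "measured", "known", "first", "only" and "open" are said of these compounds alone.

In a functional assay on MKN-45 cells (Homo sapiens) for inhibition, read by CCK-8 assay, with a stated time of 24 h (a higher number here means a weaker inhibitor, a lower number a stronger inhibitor), compound 1 `Cc1ccccc1-n1cc(-c2ccc(/C=C3\C(=O)Nc4ccccc43)cc2)nn1` gives 9770 nM. In this assay compound 2 `O=C1Nc2ccccc2/C1=C/c1ccc(-c2cn(-c3cccc(F)c3)nn2)cc1` reaches only the limit of > 20000 nM and so has no number. Compound 3 `O=C1Nc2ccccc2/C1=C/c1ccc(-c2cn(-c3cccc(Cl)c3)nn2)cc1` likewise gives only the limit > 20000 nM. The step of an at least 2.0-fold higher number from compound 1 to compound 2 (0.31 log units; beyond the scatter) and the step of an at least 2.0-fold higher number from compound 1 to compound 3 (0.31 log units; beyond the scatter) both run toward weaker inhibition, while the step that the two limits leave unreadable from compound 2 to compound 3 cannot be read, since both of its values sit at the limit of > 20000 nM in this assay, at which 2 of the 3 values shown sit. Compound 4 `O=C1Nc2ccccc2/C1=C/c1ccc(-c2cn(-c3ccc(Cl)c(C(F)(F)F)c3)nn2)cc1` is not yet measured; it differs from compound 2 by 4-chloro-3-(trifluoromethyl)phenyl in place of 3-fluorophenyl on an aromatic nitrogen. Among the measured steps, none shows a halogen-bearing phenyl on that nitrogen bringing the number back below the limit, and the step of an at least 2.0-fold higher number from compound 1 to compound 3 (0.31 log units; beyond the scatter) already places a chloro-bearing phenyl at the limit. The step that the limit leaves unreadable from compound 2 to compound 4 is therefore expected to be none that can be read against the limit. Compound 4 is expected to give about 25000 nM, in a range from 10000 nM to 60000 nM, most likely reported again only as a limit.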

Compound 4, half-maximal inhibitory concentration: 8890 nM
For compound 4 the middle estimate is 2.8-fold (0.45 log units) above the measured one, outside the stated range (below it).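

In this assay, a halogen-bearing phenyl on the aromatic nitrogen is not tied to the limit, for 4-chloro-3-(trifluoromethyl)phenyl gives an at least 2.2-fold lower number from compound 2 to compound 4 (0.35 log units; beyond the scatter) and an at least 2.2-fold lower number from compound 3 to compound 4 (0.35 log units; beyond the scatter). Against the 2-methylphenyl of compound 1, the same group gives a 1.1-fold lower number from compound 1 to compound 4 (0.04 log units; within the scatter), so these two aryl groups cannot be told apart here. Compound 2 and compound 3 hold only a limit, so the two steps to compound 4 are minimum sizes and the step between compound 2 and compound 3 cannot be read: the limit of > 20000 nM in this assay, at which 2 of the 4 values shown sit.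

The compounds shown leave open whether the chloro or the trifluoromethyl of the new group carries the step. They also leave open how an amine or a carboxylic acid on that phenyl would read in this assay.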